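Swapping methoxy for dimethylamino: an expected permeability step

The source may report more compounds than this note shows. Statements on the series, on what has been measured and on what is new or still open speak of the compounds shown alone.

Measured so far:
compound 1, `COc1cccc(Oc2ccc3c(NCCCNCc4cc(F)ccc4OC)ccnc3c2)c1`; in an ADME assay for permeability, using PAMPA, with a stated time of 30 min, at pH 7.4 (a lower number here means that the compound crosses the layer more slowly, a higher number that the compound crosses the layer faster), compound 1 gives 317 10^-6 cm/s.
compound 2, `COc1cccc(Oc2ccc3c(NCCCNCc4cccc(OC)c4O)ccnc3c2)c1`; in this assay compound 2 gives 317 10^-6 cm/s.

Compound 2 stands level with compound 1 at the digits shown. Compound 3, `COc1cccc(CNCCCNc2ccnc3cc(Oc4cccc(N(C)C)c4)ccc23)c1O`, differs from compound 2 by dimethylamino in place of methoxy on an aromatic carbon. For the measured compounds named here, the only measured step, no change at the digits printed from compound 1 to compound 2 (within the scatter), altered a different part of the molecule and left the read-out unchanged, and no measured step touches the place changed here. Without evidence of movement, compound 3 is expected to stay within the scatter, a step of a 1.1-fold lower number from compound 2 to compound 3 (0.02 log units; within the scatter). The estimate for compound 3 is 300 10^-6 cm/s, between 150 10^-6 cm/s and 600 10^-6 cm/s.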

Compound 3, apparent permeability: 317 10^-6 cm/s
For compound 3 the middle estimate is 1.1-fold (0.02 log units) below the measured one; the range from low to high includes it.
By their numbers in this assay, from the lowest: compounds 1, 2 and 3 (each within the scatter of the next).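

In this assay, for the compounds shown here, putting dimethylamino in place of methoxy on this aromatic carbon gives no change at the digits printed from compound 2 to compound 3 (within the scatter) and so adds the first measured step at this position, in a different part of the molecule from the earlier change. One nitrogen group with two carbons can therefore stand here with no visible shift in this read-out. No supporting data explain this result.

As far as these compounds go, whether a carboxylic acid or a longer amine chain at this position would leave the read-out unmoved remains open. So does whether this same swap would behave alike on another compound.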